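A few compounds are considered here, and "the series" means these few. Any claim that something is new, unique, unknown or untested is made for them only; others in the source may bear on it.

Measured so far:
compound 1 `O=C(OCc1ccccc1)SCCCCCCNC(=O)c1cc(-c2ccncc2)n[nH]1` gives 15400 nM in a functional assay on PC-3 cells (Homo sapiens) for inhibition, read by MTT assay, with a stated time of 96 h; on this read-out lower numbers stand for stronger inhibition of growth and higher numbers for weaker inhibition of growth
compound 2 `CC(C)C(=O)SCCCCCCNC(=O)c1cc(-c2ccncc2)n[nH]1` gives 22400 nM
compound 3 `C=CCOC(=O)SCCCCCCNC(=O)c1cc(-c2ccncc2)n[nH]1` gives 24800 nM

Compound 3 has the highest of the three numbers, yet its gaps to compound 2 and compound 1 both lie within the scatter, so no order among the three can be claimed. The next compound, compound 4 `CCCC(=O)SCCCCCCNC(=O)c1cc(-c2ccncc2)n[nH]1`, differs from compound 3 by propyl in place of allyloxy on a carbonyl carbon. For the measured compounds named here, the closest precedent is the step from compound 2 to compound 3, a 1.1-fold higher number from compound 2 to compound 3 (0.04 log units; within the scatter), where a thioester and a thiocarbonate gave the same read-out; the step of a 1.6-fold higher number from compound 1 to compound 3 (0.21 log units; within the scatter) was likewise flat. On that basis compound 4 is expected to sit close to compound 3, with a step of a 1.1-fold lower number from compound 3 to compound 4 (0.05 log units; within the scatter). The estimated value for compound 4 is 22000 nM, in the range 11000 nM to 44000 nM.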

Compound 4, concentration for 50% growth inhibition: 32100 nM
Compound 4: the middle estimate sits 1.5-fold (0.16 log units) below what was measured, and the stated range covers the measured number.
By their numbers in this assay, from the lowest: compounds 1, 2, 3 and 4 (each within the scatter of the next, the first and the last beyond it).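

In this assay, propyl in place of allyloxy on the carbonyl carbon gives a 1.3-fold higher number from compound 3 to compound 4 (0.11 log units; within the scatter) and so does not separate the two groups, and propyl in place of isopropyl, with a 1.4-fold higher number from compound 2 to compound 4 (0.16 log units; within the scatter) as its step, does not either. Propyl in place of benzyloxy gives a 2.1-fold higher number from compound 1 to compound 4 (0.32 log units; beyond the scatter) and is the first step in this set to pass the scatter, though only modestly. The compounds shown leave open whether a longer chain, an amine or a carboxylic acid on this carbonyl carbon would widen that gap. No evidence is available that bears on these steps.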